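Series notes: ring-nitrogen substitution on the biphenylamide core

A few compounds are considered here, and "the series" means these few. Any claim that something is new, unique, unknown or untested is made for them only; others in the source may bear on it.

Measured compounds:
compound 1 `CN1CCCc2cc(NC(=O)c3ccc(-c4ccccc4)cc3)ccc21`, 7.1
compound 2 `CN1CCCc2ccc(NC(=O)c3ccc(-c4ccccc4)cc3)cc21`, 7.5
compound 3 `O=C(Nc1ccc2c(c1)NCCC2)c1ccc(-c2ccccc2)cc1`, 7.7

In a functional assay for antagonist activity at transient receptor potential cation channel subfamily V member 1 (Homo sapiens), read by FLIPR and calcium flux (on this read-out higher numbers stand for higher potency (the scale is a negative logarithm) and lower numbers for lower potency), compound 3 gives the highest of the three numbers; compound 2 lies within the scatter of it, while compound 1 lies beyond. Among the compounds with values here, the one step at the same place, a number 0.20 log units higher from compound 2 to compound 3 (within the scatter), is within the scatter, so methyl against hydrogen on this nitrogen changes little. Compound 4 `CN(C)CCN1CCCc2ccc(NC(=O)c3ccc(-c4ccccc4)cc3)cc21` carries the change (2-(dimethylamino)ethyl in place of hydrogen on a nitrogen on an aromatic ring in a ring). Within the data shown here, no measured step tests a group larger than methyl here, so the expectation rests on compound 3 alone with 7.7 and on the small step from compound 2. Compound 4 is expected to give 7.6 (7 to 8.2), an estimated step of a number 0.10 log units lower from compound 3 to compound 4 (within the scatter) that stays within the scatter.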

Compound 4, negative logarithm of the antagonist equilibrium constant: 7.4
The estimate for compound 4 lay 0.20 log units above the measured number; low and high end bracket the measured number.
By their numbers in this assay, from the lowest: compounds 1, 4, 2 and 3 (each within the scatter of the next, the first and the last beyond it).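

In this assay, adding 2-(dimethylamino)ethyl on this nitrogen gives a number 0.30 log units lower from compound 3 to compound 4 (within the scatter), and the comparison with the methyl analogue gives a number 0.10 log units lower from compound 2 to compound 4 (within the scatter), both within the scatter. The earlier compounds shown here tested nothing larger than methyl here, whereas this position now also accepts a chain ending in a dimethylamino group with no clear loss in the number. Nothing available explains why the number holds. Open, going by these compounds, is whether a longer chain, a morpholine ring or a carboxylic acid at the chain end would also hold it. Also open, on these data alone, is whether 2-(dimethylamino)ethyl would behave alike on the core of compound 1.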